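From carboxy to trifluoromethyl: compound 3 to compound 4

A few compounds are considered here, and "the series" means these few. Any claim that something is new, unique, unknown or untested is made for them only; others in the source may bear on it.

Among the measured compounds shown here, in a physicochemical assay for solubility, read by spectrophotometry, in phosphate buffer, with a stated time of 18 h, at pH 7.4 (on this read-out lower numbers stand for lower solubility and higher numbers for higher solubility), compound 3 (`CCc1ccc(-c2nc3c(c(C)nn3-c3ccccc3)c(-c3ccccc3C(=O)O)c2C#N)cc1`) gives 33000 nM, the highest of the three numbers measured so far. Compound 4 (`CCc1ccc(-c2nc3c(c(C)nn3-c3ccccc3)c(-c3ccccc3C(F)(F)F)c2C#N)cc1`) is unmeasured and differs from it at one place: trifluoromethyl in place of carboxy on an aromatic carbon. This is trifluoromethyl in place of carboxy on an aromatic carbon.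

Compound 1 (`CCc1ccc(-c2nc3c(c(C)nn3-c3ccccc3)c(-c3ccccc3C#N)c2C#N)cc1`) gives 2400 nM and compound 2 (`CCc1ccc(-c2nc3c(c(C)nn3-c3ccccc3)c(-c3ccccc3C)c2C#N)cc1`) gives 6000 nM; neither carries carboxy. Two measured steps introduce carboxy: a 14-fold higher number from compound 1 to compound 3 (1.14 log units; beyond the scatter), which is large, and a 5.5-fold higher number from compound 2 to compound 3 (0.74 log units; beyond the scatter), which is modest. Methyl in place of cyano gives a 2.5-fold higher number from compound 1 to compound 2 (0.40 log units; beyond the scatter), also modest.

For the measured compounds named here, no trifluoromethyl compound has been measured, so the comparison rests on these three steps. Removing carboxy is expected to reverse much of the gain and bring the number back near those of the two compounds without it. In this assay, the expected step is a 9.4-fold lower number from compound 3 to compound 4 (0.97 log units; beyond the scatter), a large fall beyond the scatter. For compound 4, the estimate is 3500 nM, with an expected range of 1200 nM to 9000 nM.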

Compound 4, solubility: 11000 nM
Compound 4: middle estimate off by 3.1-fold (0.50 log units), on the low side; measured number outside the range, above it.
By their numbers in this assay, from the lowest: compound 1; then compounds 2 and 4 (each within the scatter of the next); then compound 3.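

In this assay, among the compounds shown here, carboxy is no longer the only group at this position that stands clear of cyano: trifluoromethyl does too (a 4.6-fold higher number from compound 1 to compound 4 (0.66 log units; beyond the scatter)). Carboxy still gives the highest number of the four, but the step away from it to trifluoromethyl is only modest (a 3.0-fold lower number from compound 3 to compound 4 (0.48 log units; beyond the scatter)). Trifluoromethyl and methyl cannot be told apart at this position (a 1.8-fold higher number from compound 2 to compound 4 (0.26 log units; within the scatter)), so of the groups without carboxy only cyano stands apart from the others.

Nothing at hand accounts for these numbers. As far as these compounds go, whether an amine, a primary amide or a methoxy group at this position would read near compound 3 or near compound 4 stays open, as does whether the same order holds with another group in place of the ethyl chain.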